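The source may hold more compounds than are shown below. What is called first, only, known or untested is meant among the compounds shown, and "the series" means these compounds.

Two compounds of this series carry numbers in a functional assay on DLD-1 cells (Homo sapiens) for antiproliferative activity, read by trypan blue exclusion; a lower number here means a stronger inhibitor, a higher number a weaker inhibitor. Compound 1 `COc1ccc(/C=C/S(=O)(=O)Cc2ccc(OC)cc2)cc1` reaches only the limit of the assay: in this assay compound 1 gives > 20000 nM, a limit and not a number. Compound 2 `COc1cc(OC)c(/C=C/S(=O)(=O)Cc2ccc(OC)c(OC)c2OC)c(OC)c1` does give a number; in this assay compound 2 gives 15000 nM. With compound 1 sitting at the limit of > 20000 nM in this assay, at which 1 of the 2 values shown sits, its place among the shown numbers cannot be fixed, and nothing can be said of how it compares with compound 2 beyond the two values themselves. Within the data shown here, no pair of measured compounds differs in a single place, so no measured step exists.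

Compound 3 `COc1ccc(CS(=O)(=O)/C=C/c2ccc([N+](=O)[O-])cc2)cc1` is the unmeasured compound. It differs from compound 1 in one place: nitro in place of methoxy on an aromatic carbon. Nothing measured here tells how a nitro compares with a methoxy at that place, so the expectation rests only on the two measured values, both lying at the high end of the scale. For compound 3 in this assay the estimate is 5000 nM, with a range from 800 nM to 30000 nM. That estimate means a step of an at least 4.0-fold lower number from compound 1 to compound 3 (0.60 log units; beyond the scatter), expected toward stronger inhibition, though its size is uncertain since it starts from a limit, and a second limit rather than a number remains possible.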

Compound 3, half-maximal inhibitory concentration: 5000 nM
For compound 3 middle estimate and measured number coincide at the digits printed; the measured number falls inside the stated range.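

In this assay, the aromatic carbon para to a large group now has its first readable step: nitro in place of methoxy gives an at least 4.0-fold lower number from compound 1 to compound 3 (0.60 log units; beyond the scatter), toward stronger inhibition. Among these compounds, this position therefore responds to a single exchange, which the earlier compounds could not show, and compound 3 gives a number where compound 1 gives none. The size of the step remains a bound, since its starting point is a limit and not a number: the limit of > 20000 nM in this assay, at which 1 of the 3 values shown sits.

Only one exchange at this position is shown, so it remains open whether the shift is particular to nitro or would also appear with chlorine, an amine or a nitrile at the same place. Also open, on these data alone, is whether nitro in place of methoxy on the other six-membered aromatic ring of the shared core would give a comparable step.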